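Thioether and sulfone pairs with two five-membered head groups

The source may report more compounds than this note shows. Statements on the series, on what has been measured and on what is new or still open speak of the compounds shown alone.

Measured so far:
compound 1, `Nc1nnc(-c2ccccc2Sc2ccccc2)o1`, 16.6%
compound 2, `Nc1nnc(-c2ccccc2S(=O)(=O)c2ccccc2)o1`, 40.5%
compound 3, `S=c1[nH]nc(-c2ccccc2Sc2ccccc2)[nH]1`, 49.4%

In a functional assay on the whole organism (strain NMRI) for inhibition, with Mus musculus as the target, in the formalin test, with a stated time of 30 min, at a dose of 30 umol/kg by the intraperitoneal route (a higher number here means more inhibition at the dose given (going by the name of the read-out), a lower number less inhibition), compound 1 gives 16.6% and compound 3 gives 49.4%. The two differ by a group of 6 heavy atoms (2 carbon, 3 nitrogen, 1 sulfur; one five-membered aromatic ring with 3 hetero atoms) in place of a group of 6 heavy atoms (2 carbon, 3 nitrogen, 1 oxygen; one five-membered aromatic ring with 3 hetero atoms), on an aromatic carbon and the step is a number 32.8 percentage points higher from compound 1 to compound 3 (beyond the scatter). Compound 2, in this assay, gives 40.5%; the difference between the cores of compound 1 and compound 2 is not broken down here. The values of compound 2 and compound 3 lie within the scatter of each other, so no order between the two is claimed; each of them stands beyond the scatter above compound 1.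

Not yet measured is compound 4, `O=S(=O)(c1ccccc1)c1ccccc1-c1n[nH]c(=S)[nH]1`. It differs from compound 2 by a group of 6 heavy atoms (2 carbon, 3 nitrogen, 1 sulfur; one five-membered aromatic ring with 3 hetero atoms) in place of a group of 6 heavy atoms (2 carbon, 3 nitrogen, 1 oxygen; one five-membered aromatic ring with 3 hetero atoms), on an aromatic carbon. For the measured compounds named here, this is the same kind of change as the one from compound 1 to compound 3, but not on the same core: the core of compound 2 is not that of compound 1, and the place of each change is given with its difference.

Going by the values given here, the step from compound 2 to compound 4 in this assay is expected to be a number 21.5 percentage points higher from compound 2 to compound 4 (beyond the scatter), smaller than the one seen from compound 1 to compound 3, because a number 32.8 percentage points higher from compound 1 to compound 3 (beyond the scatter) started from a lower value, and compound 2 already stands higher. Among the compounds with values here, with only one example of the change, the estimate carries a wide range. For compound 4 in this assay the expected value is 62%, with a range from 42% to 82%.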

Compound 4, a percentage reported as inhibition, in the whole organism at one dose (the size of the read-out at that dose, not a potency): 31.2%
Compound 4: middle estimate off by 30.8 percentage points, on the high side; the measured number lies below the stated range.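

The step from the 5-amino-1,3,4-oxadiazol-2-yl group to the entering group does not carry over from the thioether to the sulfone in this assay: a number 9.3 percentage points lower from compound 2 to compound 4 (within the scatter) gives no order between the two compounds, in contrast to a number 32.8 percentage points higher from compound 1 to compound 3 (beyond the scatter). The transfer therefore fails on this pair of cores, with the outcome of the same change depending on the core it is made on: the same change on two cores in this assay, a number 32.8 percentage points higher (beyond the scatter) from compound 1 to compound 3 and a number 9.3 percentage points lower (within the scatter) from compound 2 to compound 4, 42.1 percentage points apart, beyond the scatter of two such steps This rests on one pair of steps at a single dose, so it shows neither why the cores differ nor how the change would behave on any third core.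

The compounds shown leave open whether a sulfoxide in place of the thioether or sulfone sulfur would give a step closer to that of the thioether or to that of the sulfone. They also leave open how a 5-amino-1,3,4-thiadiazol-2-yl group would behave on either core, which would separate the exchange of the ring oxygen for sulfur from the other differences between the leaving and the entering group.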